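The compounds below may be only part of what the source reports. "The series", "measured", "known", "first", "only" and "open" are said of these compounds alone.

Three compounds built on the shared core have so far been run in a functional assay on the whole organism for inhibition, with Mus musculus as the target, at a dose of 25 mg/kg by the oral route; on this read-out lower numbers stand for less inhibition and higher numbers for more inhibition at the one dose given (going by the name of the read-out). Compound 1 `Fc1cccc(N2CCN(CCCCOc3ccc4c(c3)CCC4)CC2)c1` gives 15%. Compound 2 `Clc1cc(Cl)cc(N2CCN(CCCOc3ccc4c(c3)CCC4)CC2)c1` gives 0%, and compound 3 `FC(F)(F)c1cccc(N2CCN(CCCCCOc3ccc4c(c3)CCC4)CC2)c1` gives 33%. Among these three numbers compound 1 stands second highest: its nearest neighbour is compound 2, which sits lower by a gap beyond the usual scatter, while compound 3 sits higher by a gap that is also beyond the scatter. Among the compounds with values here, no pair of measured compounds differs in one place only, so the measured numbers yield no isolated step to lean on; the two other compounds differ from compound 1 both in the aryl group on the ring nitrogen and in the length of the chain to the ether oxygen.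

Compound 4 `COc1ccccc1N1CCN(CCCCOc2ccc3c(c2)CCC3)CC1` is the next compound due in this assay. Relative to compound 1, its structure differs as follows: 2-methoxyphenyl in place of 3-fluorophenyl on an amine nitrogen in a ring. Within the data shown here, nothing among the measured compounds separates the effect of the group on the amine nitrogen from that of the chain, so the direction of this change cannot be read from the data. The expected step is a number 3 percentage points higher from compound 1 to compound 4 (within the scatter), which is taken to lie within the scatter. For compound 4 the expected value in this assay is therefore 18%, with a range from 0% to 45%.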

Compound 4, a percentage reported as inhibition, in the whole organism at one dose (the size of the read-out at that dose, not a potency): 33%
For compound 4 the middle estimate is 15 percentage points below the measured one, and the stated range covers the measured number.
By their numbers in this assay, from the lowest: compound 2; then compound 1; then compounds 3 and 4 (each within the scatter of the next).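

With the rest of compound 1 held constant, 2-methoxyphenyl in place of 3-fluorophenyl on the amine nitrogen in a ring gives a number 18 percentage points higher from compound 1 to compound 4 (beyond the scatter) in this assay. Within the data shown here, this is the first change that can be read in one place, and it shows that the aryl group on this nitrogen can move the number beyond the scatter, though the step is modest. The change swaps a fluorine for a methoxy group, adds a hydrogen-bond acceptor and moves the substituent to a different ring position all at once, and no measurement available here bears on why the number rises.

A 2-fluorophenyl or a 3-methoxyphenyl on the same nitrogen would show whether the step follows the substituent or its ring position, and a 2-hydroxyphenyl would test the methoxy group itself. The effect of chain length also remains open, since no pair of compounds shown varies the chain alone, and a shorter or longer chain carrying the 2-methoxyphenyl group would separate it from the effect of the aryl group.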